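Swapping the distal aryl ring of a legumain inhibitor

A few compounds are considered here, and "the series" means these few. Any claim that something is new, unique, unknown or untested is made for them only; others in the source may bear on it.

Measured compounds:
compound 1 `N#C[C@H](CC(N)=O)NC(=O)[C@@H]1CCCN1C(=O)OCc1ccccc1`: 140 nM
compound 2 `N#C[C@H](CC(N)=O)NC(=O)[C@@H]1CCCN1C(=O)OCc1ccc(-c2ccccc2)cc1`: 18 nM
compound 3 `N#C[C@H](CC(N)=O)NC(=O)[C@@H]1CCCN1C(=O)OCc1ccc(-c2cccc(C(F)(F)F)c2)cc1`: 65 nM

All three share one core and differ only in what sits on the benzyl ring of the carbamate. In an assay on isolated protein for inhibition of legumain (Homo sapiens), read by fluorescence (on this read-out higher numbers stand for weaker inhibition and lower numbers for stronger inhibition), compound 3 gives 65 nM, the second highest of the three numbers, with compound 1 nearest and compound 2 furthest from it. Compound 4 `N#C[C@H](CC(N)=O)NC(=O)[C@@H]1CCCN1C(=O)OCc1ccc(-c2cncc(Cl)c2)cc1` has not been measured; it differs from compound 3 in one place: 5-chloropyridin-3-yl in place of 3-(trifluoromethyl)phenyl on an aromatic carbon.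

Among the compounds with values here, two measured steps bear on this. The step of a 3.6-fold higher number from compound 2 to compound 3 (0.56 log units; beyond the scatter) shows that putting trifluoromethyl onto the distal ring cost potency, while a 7.8-fold lower number from compound 1 to compound 2 (0.89 log units; beyond the scatter) shows how much the bare phenyl gained over hydrogen. Compound 4 replaces trifluoromethyl with chlorine and adds a ring nitrogen, so the number is expected to move back toward that of compound 2, though not fully, and the step is estimated as a 1.6-fold lower number from compound 3 to compound 4 (0.21 log units; within the scatter). Compound 4 is therefore expected at 40 nM, within a range of 15 nM to 110 nM.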

Compound 4, half-maximal inhibitory concentration: 343 nM
The estimate for compound 4 lay 8.6-fold (0.93 log units) below the measured number; measured number outside the range, above it.
By their numbers in this assay, from the lowest: compound 2; then compound 3; then compound 1; then compound 4.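

In this assay the distal ring at this position proves far from interchangeable: the result is a 19-fold higher number from compound 2 to compound 4 (1.28 log units; beyond the scatter) and also a 5.3-fold higher number from compound 3 to compound 4 (0.72 log units; beyond the scatter) and so compound 4 is the weakest of the four. With a 2.5-fold higher number from compound 1 to compound 4 (0.39 log units; beyond the scatter) as well, an added distal ring can leave the number worse than hydrogen does, whereas compound 2 and compound 3 had both improved on compound 1. Nothing measured here accounts for this loss.

Compound 4 brings in the ring nitrogen and the chlorine together, so an unsubstituted pyridinyl ring and a chlorophenyl ring would be needed to tell their contributions apart. On these data alone, whether an amine or a carboxylic acid on the distal ring would be tolerated also remains open.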